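Swapping a Cyclohexyl Ketone Arm for a Methylbenzyl Group

A few compounds are considered here, and "the series" means these few. Any claim that something is new, unique, unknown or untested is made for them only; others in the source may bear on it.

Going by the values given here, compound 2 `O=C(O)c1ccc(C(=O)c2ccc(C(=O)C3CCCCC3)cc2)cc1` holds the lowest of the two numbers so far: in an assay on CHO cells for inhibition of 3-oxo-5-alpha-steroid 4-dehydrogenase 2 (Homo sapiens) (on this read-out lower numbers stand for stronger inhibition and higher numbers for weaker inhibition), compound 2 gives 30 nM, whereas compound 1 `O=C(O)c1ccc(C(=O)c2ccc(C(=O)c3ccccc3)cc2)cc1` gives 40 nM. Among the compounds with values here, the only measured step, a 1.3-fold lower number from compound 1 to compound 2 (0.12 log units; within the scatter), stays within the scatter. Compound 3 `Cc1ccc(Cc2ccc(C(=O)c3ccc(C(=O)O)cc3)cc2)cc1` differs from compound 2 by 4-methylbenzyl in place of cyclohexylcarbonyl on an aromatic carbon. Within the data shown here, that earlier step touched only the ring on the carbonyl carbon, so no measured step bears directly on removing the carbonyl itself. Compound 3 is therefore expected to change little, a 1.7-fold higher number from compound 2 to compound 3 (0.22 log units; within the scatter), with an estimate of 50 nM and a range from 15 nM to 200 nM.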

Compound 3, inhibition constant: 15 nM
Estimate against measurement, compound 3: 3.3-fold (0.52 log units) above; the range from low to high includes it.
By their numbers in this assay, from the lowest: compounds 3, 2 and 1 (each within the scatter of the next, the first and the last beyond it).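

The aromatic carbon para to a large group accepts loss of the arm's carbonyl in this assay with a 2.0-fold lower number from compound 2 to compound 3 (0.30 log units; within the scatter) as the exchange of cyclohexylcarbonyl for 4-methylbenzyl. Going by these compounds alone, measured against the benzoyl arm, the same 4-methylbenzyl group gives a 2.7-fold lower number from compound 1 to compound 3 (0.43 log units; beyond the scatter) and so provides the first step here beyond the scatter, although a modest one. Nothing available on these compounds accounts for this result.

On these data alone, it remains open whether the methyl of 4-methylbenzyl contributes to the value. Also open, as far as these compounds go, is how an unsubstituted benzyl, a methoxy group or a longer alkyl chain would behave at this position.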